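A few compounds are considered here, and "the series" means these few. Any claim that something is new, unique, unknown or untested is made for them only; others in the source may bear on it.

Compound 1, `C[Se]c1nc(NCc2ccccc2)c2ccccc2n1`: 15800 nM
Compound 2, `CSc1nc(NCc2ccccc2)c2ccccc2n1`: 41500 nM
Compound 3, `CSc1ccc(CNc2nc(SC)nc3ccccc23)cc1`: 47300 nM

All three were tested in a functional assay on MCF7 cells (Homo sapiens) for cytotoxicity, read by MTT assay, with a stated time of 72 h; on this read-out lower numbers stand for stronger inhibition of growth and higher numbers for weaker inhibition of growth. In this assay compound 2 gives 41500 nM and compound 3 gives 47300 nM, values that lie within the usual scatter of each other. The two cores differ by methylsulfanyl in place of hydrogen on an aromatic carbon, and that difference gave a 1.1-fold higher number from compound 2 to compound 3 (0.06 log units; within the scatter). Compound 1 differs from compound 2 by a group of 2 heavy atoms (1 carbon, 1 selenium; no ring) in place of a group of 2 heavy atoms (1 carbon, 1 sulfur; no ring), on an aromatic carbon, which gave a 2.6-fold lower number from compound 2 to compound 1 (0.42 log units; beyond the scatter).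

Compound 4, `CSc1ccc(CNc2nc([Se]C)nc3ccccc23)cc1`, has not yet been measured. It differs from compound 3 by a group of 2 heavy atoms (1 carbon, 1 selenium; no ring) in place of a group of 2 heavy atoms (1 carbon, 1 sulfur; no ring), on an aromatic carbon. Within the data shown here, this is the same kind of change as the one made from compound 2 to compound 1, though made on the core of compound 3 rather than on the core of compound 2. Because a 1.1-fold higher number from compound 2 to compound 3 (0.06 log units; within the scatter) shows the core change itself barely moved the number, the earlier step is taken as the guide. The expected step is a 2.6-fold lower number from compound 3 to compound 4 (0.42 log units; beyond the scatter), resting on a 2.6-fold lower number from compound 2 to compound 1 (0.42 log units; beyond the scatter). In this assay compound 4 is therefore estimated at 18000 nM, likely between 8000 nM and 40000 nM.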

Compound 4, concentration for 50% growth inhibition: 54100 nM
For compound 4 the middle estimate is 3.0-fold (0.48 log units) below the measured one; the measured number lies above the stated range.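

In this assay, exchanging the sulfur of the methylsulfanyl group for selenium gave a 1.1-fold higher number from compound 3 to compound 4 (0.06 log units; within the scatter), so the lower number seen on the core of compound 2 did not return on the core of compound 3, and the two steps do not match: the same change on two cores in this assay, a 2.6-fold lower number (0.42 log units; beyond the scatter) from compound 2 to compound 1 and a 1.1-fold higher number (0.06 log units; within the scatter) from compound 3 to compound 4, 3.0-fold (0.48 log units) apart, beyond the scatter of two such steps. Read the other way, adding methylsulfanyl to the selenium compound gave a 3.4-fold higher number from compound 1 to compound 4 (0.53 log units; beyond the scatter), whereas the same addition made no difference beyond the scatter on the sulfur compound: the same change on two cores in this assay, a 1.1-fold higher number (0.06 log units; within the scatter) from compound 2 to compound 3 and a 3.4-fold higher number (0.53 log units; beyond the scatter) from compound 1 to compound 4, 3.0-fold (0.48 log units) apart, beyond the scatter of two such steps. The effect of each change therefore depends on the other in these four compounds, but this single set of four does not show why, nor how either change would behave on any other core.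

As far as these compounds go, it remains open whether the lower number seen with selenium would return if a methoxy group, a chlorine atom or an amine stood in place of the added methylsulfanyl. From the compounds shown here alone, whether a longer chain on the selenium would behave like the methyl group also remains open.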